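Methyl to fluoro in the antiproliferative series

The source may report more compounds than this note shows. Statements on the series, on what has been measured and on what is new or still open speak of the compounds shown alone.

Measured in a functional assay on MCF7 cells (Homo sapiens) for antiproliferative activity, read by MTT assay, with a stated time of 72 h; a lower number here means a stronger inhibitor, a higher number a weaker inhibitor:
compound 1 `COc1cc(-n2cnc3ccc(-c4ccccc4)cc32)cc(OC)c1OC` gives 2290 nM
compound 2 `COc1cc(-n2cnc3ccc(-c4ccc(C)cc4)cc32)cc(OC)c1OC` gives 110 nM

Compound 2 holds the lower of the two numbers. Compound 3 `COc1cc(-n2cnc3ccc(-c4ccc(F)cc4)cc32)cc(OC)c1OC` differs from it by fluoro in place of methyl on an aromatic carbon. Within the data shown here, the only measured step that bears on this is the large 21-fold lower number from compound 1 to compound 2 (1.32 log units; beyond the scatter), for methyl in place of hydrogen on an aromatic carbon. Among the measured compounds shown here, no measurement yet shows how fluoro compares. Part of that gain is expected to be lost, so a higher number is expected in this assay. The expected change is a 4.1-fold higher number from compound 2 to compound 3 (0.61 log units; beyond the scatter). The estimate for compound 3 is 450 nM, with an expected range of 130 nM to 1600 nM.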

Compound 3, half-maximal inhibitory concentration: 1770 nM
Beside the measured number, compound 3's estimate is 3.9-fold (0.59 log units) below it, and the stated range ends below it.
By their numbers in this assay, from the lowest: compound 2; then compounds 3 and 1 (each within the scatter of the next).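

In this assay, replacing 4-methylphenyl with 4-fluorophenyl gives a 16-fold higher number from compound 2 to compound 3 (1.21 log units; beyond the scatter) and removes the gain seen with methyl. Fluoro in place of hydrogen on this aromatic carbon gives a 1.3-fold lower number from compound 1 to compound 3 (0.11 log units; within the scatter) and so leaves the two compounds level within the scatter. Among these compounds, only methyl at this position stands apart, and nothing at hand gives a reason for the difference between methyl and fluoro.

From the compounds shown here alone, whether the gain is specific to methyl remains open. Ethyl, methoxy or chloro at this position would test how far it extends.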